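Methoxy for Fluoro on a Benzofuran Ester Series

This account rests on a few compounds, and the source may have more. Where it says the series, first, only, none or still open, it means among the compounds named here.

Compound 1 `CCOC(=O)c1c(-c2ccc(OC)cc2)oc2ccc(OCCCCCCN3C(=O)C(=O)c4cc(F)ccc43)cc12` and compound 2 `CCOC(=O)c1c(-c2ccc(F)cc2)oc2ccc(OCCCCCCN3C(=O)C(=O)c4cc(F)ccc43)cc12` were compared in an ADME assay on Vero cells (Chlorocebus sabaeus) for cytotoxicity, read by MTT assay, with a stated time of 72 h; on this read-out lower numbers stand for higher toxicity in this test and higher numbers for lower toxicity in this test. In this assay compound 1 gives 128000 nM while compound 2 gives 512000 nM. The change between them, (methoxy in place of fluoro on an aromatic carbon), made the step of a 4.0-fold lower number from compound 2 to compound 1 (0.60 log units; beyond the scatter). Compound 3 `CCOC(=O)c1c(-c2ccc(F)cc2)oc2ccc(OCCCN3C(=O)C(=O)c4ccccc43)cc12` carries a different core; the difference between the two cores is not broken down here. In this assay compound 3 gives 256000 nM, which sits between the values of compound 1 and compound 2. Compound 4 `CCOC(=O)c1c(-c2ccc(OC)cc2)oc2ccc(OCCCN3C(=O)C(=O)c4ccccc43)cc12` is not yet measured and differs from compound 3 by methoxy in place of fluoro on an aromatic carbon, the same change that was seen from compound 2 to compound 1. Because a 4.0-fold lower number from compound 2 to compound 1 (0.60 log units; beyond the scatter) was observed, the expected step is a 4.0-fold lower number from compound 3 to compound 4 (0.60 log units; beyond the scatter). For compound 4 the estimated value in this assay is 64000 nM, with a range from 30000 nM to 160000 nM.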

Compound 4, half-maximal cytotoxic concentration: 64000 nM
For compound 4 middle estimate and measured number coincide at the digits printed, and the stated range covers the measured number.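

Going from 4-fluorophenyl to 4-methoxyphenyl in this assay gave a 4.0-fold lower number from compound 3 to compound 4 (0.60 log units; beyond the scatter). The same change thus gave matching steps on the two cores: the same change on two cores in this assay, a 4.0-fold lower number (0.60 log units; beyond the scatter) from compound 2 to compound 1 and a 4.0-fold lower number (0.60 log units; beyond the scatter) from compound 3 to compound 4, 1.0-fold (0.00 log units) apart, within the scatter of two such steps. Among the compounds shown here, this shows that the change carried over between these two cores in this assay, but it rests on only two pairs and does not show that the step would hold on any other core, nor why the number moves.

The compounds shown leave open whether an amine or a carboxylic acid in place of the fluoro would follow the same course. Going by these compounds, it also remains open whether the step would persist with a longer chain or with a carboxylic acid in place of the ethyl ester.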